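Chlorines on the Aryl Ether of a Triazine Series

The source may report more compounds than this note shows. Statements on the series, on what has been measured and on what is new or still open speak of the compounds shown alone.

Compound 1 `Cc1cccc(OCc2nc(N)nc(N3CCN(C)CC3)n2)c1` and compound 2 `Cc1ccc(OCc2nc(N)nc(N3CCN(C)CC3)n2)cc1` share a core and differ only in where the methyl sits on the phenyl ring attached through an oxygen on a saturated carbon. In an assay on HEK293 cells for displacement of a labelled ligand from 5-hydroxytryptamine receptor 6 (Homo sapiens), read by radioligand binding, with a stated time of 1 h (on this read-out higher numbers stand for weaker inhibition and lower numbers for stronger inhibition), compound 1 gives 207 nM, and compound 2 gives 235 nM; the step of a 1.1-fold higher number from compound 1 to compound 2 (0.06 log units; within the scatter) lies within the scatter, so the two stand level. Of the two numbers measured, compound 2 has the higher one, but its nearest neighbour, compound 1, is within the scatter of it.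

Compound 3 `CN1CCN(c2nc(N)nc(COc3ccc(Cl)cc3Cl)n2)CC1` is reached from compound 2 by the change (2,4-dichlorophenyl in place of 4-methylphenyl on an oxygen on a saturated carbon). Among the measured compounds shown here, the one measured step, from compound 1 to compound 2, tells only that moving a methyl on this ring changes little; no measured step introduces chlorine at this place. The data therefore give no ground to expect a step beyond the scatter in this assay, though they cannot rule one out. Compound 3 is expected at about 180 nM, within 60 nM to 550 nM, a step of a 1.3-fold lower number from compound 2 to compound 3 (0.12 log units; within the scatter).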

Compound 3, inhibition constant: 128 nM
Compound 3: the middle estimate sits 1.4-fold (0.15 log units) above what was measured; the measured number falls inside the stated range.
By their numbers in this assay, from the lowest: compounds 3, 1 and 2 (each within the scatter of the next).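

In this assay, 2,4-dichlorophenyl in place of 4-methylphenyl on an oxygen on a saturated carbon gives a 1.8-fold lower number from compound 2 to compound 3 (0.26 log units; within the scatter) and the same group in place of 3-methylphenyl gives a 1.6-fold lower number from compound 1 to compound 3 (0.21 log units; within the scatter) so neither exchange moves the number beyond the scatter. The earlier pair showed only that a methyl could stand in either of two places on this phenyl ring without a step beyond the scatter; compound 3 adds that a phenyl ring carrying two chlorines, with 8 heavy atoms in place of 7, also stands level with both methyl compounds, and no order can be drawn among the three. No measurement at hand speaks to why these groups stand level.

The compounds shown leave open how a single chlorine would read, as in 4-chlorophenyl or 2-chlorophenyl, since the two chlorines of compound 3 arrive together and their separate contributions cannot be told apart. They also leave open whether an amine or a carboxylic acid on this phenyl ring, or a longer chain in place of the ring, would give a step beyond the scatter.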